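From compound 3 to compound 4: a side-chain exchange

This account rests on a few compounds, and the source may have more. Where it says the series, first, only, none or still open, it means among the compounds named here.

In a functional assay on MCF7 cells (Homo sapiens) for antiproliferative activity, read by sulforhodamine B assay, with a stated time of 48 h (a higher number here means a weaker inhibitor, a lower number a stronger inhibitor), compound 1 (`CCCCN(C)C(=O)CCCOc1cc(OC)c(OC)c2oc(-c3ccc(OC)cc3)c(O)c(=O)c12`) gives > 40000 nM, a limit of the assay. Compound 2 (`COc1ccc(-c2oc3c(OC)c(OC)cc(OCCCC(=O)N4CCN(C)CC4)c3c(=O)c2O)cc1`) gives > 40000 nM, also a limit. For the measured compounds named here, compound 3 (`CCCCN(C)C(=O)CCCCOc1cc(OC)c(OC)c2oc(-c3ccc(OC)cc3)c(O)c(=O)c12`) gives 22300 nM, the only actual number so far; the other two compounds sit at the limit of > 40000 nM in this assay, at which 2 of the 3 values shown sit.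

Compound 4 (`COc1ccc(-c2oc3c(OC)c(OC)cc(OC(C)CN(C)C)c3c(=O)c2O)cc1`) follows from compound 3 by one exchange: 1-((dimethylamino)methyl)ethyl in place of 4-(butyl(methyl)carbamoyl)butyl on an oxygen on an aromatic ring. The nearest measured changes are an at least 1.7-fold lower number from compound 1 to compound 3 (0.25 log units; that floor lies within the scatter) and an at least 1.7-fold lower number from compound 2 to compound 3 (0.25 log units; that floor lies within the scatter), both with floors within the scatter, while a step that the two limits leave unreadable from compound 1 to compound 2 gives no usable size. On these steps, nothing beyond the scatter is expected: the estimate is a 1.1-fold lower number from compound 3 to compound 4 (0.05 log units; within the scatter). Compound 4 is expected at 20000 nM, with an estimated range of 7000 nM to 40000 nM.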

Compound 4, half-maximal inhibitory concentration: 7200 nM
The estimate for compound 4 lay 2.8-fold (0.44 log units) above the measured number; low and high end bracket the measured number.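

For the compounds shown here, on an oxygen on an aromatic ring, 1-((dimethylamino)methyl)ethyl in place of 4-(butyl(methyl)carbamoyl)butyl gives the first readable step beyond the scatter in this assay: a 3.1-fold lower number from compound 3 to compound 4 (0.49 log units; beyond the scatter). Against the two shorter amide side chains, the floors also clear the scatter: an at least 5.5-fold lower number from compound 2 to compound 4 (0.74 log units; beyond the scatter) and an at least 5.5-fold lower number from compound 1 to compound 4 (0.74 log units; beyond the scatter). Both floors rest on a limit of the assay: the limit of > 40000 nM in this assay, at which 2 of the 4 values shown sit.

This single exchange does not separate the amine from the shorter chain or the lost carbonyl. Open also is how a straight propyl chain carrying the dimethylamino group, or a morpholine in its place, would read.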